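The source may report more compounds than this note shows. Statements on the series, on what has been measured and on what is new or still open speak of the compounds shown alone.

Working notes on the lipopeptide series.

Three compounds carry the shared core of compound 1 `CCCCCCCCCCCC(=O)OC[C@H](CSC[C@@H](N)C(=O)NCCO)OC(=O)CCCCCCCCCCC` and differ only at the amide-type nitrogen. In an assay on HEK293 cells for agonist activity at Toll-like receptor 2 (Homo sapiens) (on this read-out lower numbers stand for an effect already at smaller amounts and higher numbers for an effect only at larger amounts of compound), compound 1 gives 24 nM. Compound 2 `CCCCCCCCCCCC(=O)OC[C@H](CSC[C@@H](N)C(=O)NCCCS(=O)(=O)O)OC(=O)CCCCCCCCCCC` gives 5560 nM in this assay, and compound 3 `CCCCCCCCCCCC(=O)OC[C@H](CSC[C@@H](N)C(=O)NC(C)c1ccccc1)OC(=O)CCCCCCCCCCC` gives 9900 nM. Compound 3 stands highest of the three numbers: its nearest neighbour is compound 2, where the gap a 1.8-fold higher number from compound 2 to compound 3 (0.25 log units; within the scatter) lies within the scatter, and its furthest is compound 1, from which a 410-fold higher number from compound 1 to compound 3 (2.62 log units; beyond the scatter).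

Compound 4 `CCCCCCCCCCCC(=O)OC[C@H](CSC[C@@H](N)C(=O)N[C@@H](CC)COCC(=O)O)OC(=O)CCCCCCCCCCC` is not yet measured. It differs from compound 3 in that (1-((carboxymethoxy)methyl)propyl in place of 1-phenylethyl on an amide-type nitrogen). For the measured compounds named here, two measured steps bear on this. The change from the 2-hydroxyethyl group of compound 1 to the 1-phenylethyl group of compound 3 was large, a 410-fold higher number from compound 1 to compound 3 (2.62 log units; beyond the scatter), while the change from the 3-sulfopropyl group of compound 2 to the same 1-phenylethyl group, a 1.8-fold higher number from compound 2 to compound 3 (0.25 log units; within the scatter), was not. The entering 1-((carboxymethoxy)methyl)propyl group resembles the substituent of compound 1 in carrying a hydrogen-bond donor and acceptors, yet the substituent of compound 2 also carries such groups and gave a high number; the two precedents point in opposite directions. A step toward lower numbers is expected but with wide uncertainty, so the estimated step is a 6.6-fold lower number from compound 3 to compound 4 (0.82 log units; beyond the scatter). Compound 4 is thus expected to give about 1500 nM in this assay, within a range from 150 nM to 15000 nM.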

Compound 4, half-maximal effective concentration: 6500 nM
For compound 4 the middle estimate is 4.3-fold (0.64 log units) below the measured one, within the range that was stated.
By their numbers in this assay, from the lowest: compound 1; then compounds 2, 4 and 3 (each within the scatter of the next).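

In this assay, 1-((carboxymethoxy)methyl)propyl in place of 1-phenylethyl on the amide-type nitrogen gives a 1.5-fold lower number from compound 3 to compound 4 (0.18 log units; within the scatter), and the same group in place of 3-sulfopropyl gives a 1.2-fold higher number from compound 2 to compound 4 (0.07 log units; within the scatter), so three differently built substituents, one with an aromatic ring and two without, now lie within the scatter of one another. In place of 2-hydroxyethyl, the same group gives a 270-fold higher number from compound 1 to compound 4 (2.43 log units; beyond the scatter), which leaves compound 1 alone at the low end of the series and shows that a hydrogen-bond donor and acceptors on this substituent do not by themselves bring the number down to that of compound 1. Nothing shown here accounts for this gap.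

The compounds shown leave open whether the low number depends on the hydroxy group, on the length of the 2-hydroxyethyl chain, or on both; a 3-hydroxypropyl or 2-aminoethyl group at this nitrogen would separate these. They also leave open whether a carboxylic acid on a simple unbranched chain behaves like the 1-((carboxymethoxy)methyl)propyl group, and what the defined stereocentre of that group contributes.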